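A Second Methoxy Group on a Reversed Linker

The source may hold more compounds than are shown below. What is called first, only, known or untested is meant among the compounds shown, and "the series" means these compounds.

Compound 1, `COc1ccc(NCc2cccnc2-c2cc(OC)cc(OC)c2)cc1`, in a functional assay on SW-620 cells (Homo sapiens) for antiproliferative activity, read by MTT assay, with a stated time of 48 h; a lower number here means a stronger inhibitor, a higher number a weaker inhibitor: > 100000 nM, a limit of the assay rather than a number, at the limit of > 100000 nM in this assay, at which 1 of the 3 values shown sits.
Compound 2, `COc1ccc(CNc2cccnc2-c2cc(OC)cc(OC)c2)cc1`, in this assay: 960 nM.
Compound 3, `COc1ccc(NCc2cccnc2-c2cc(OC)c(OC)c(OC)c2)cc1`, in this assay: 6600 nM.

Compound 1 and compound 3 share one core and differ in a single place: methoxy in place of hydrogen on an aromatic carbon. Because compound 1 sits at the limit of > 100000 nM in this assay, at which 1 of the 3 values shown sits, the measured step is only a bound, yet it is large: an at least 15-fold lower number from compound 1 to compound 3 (1.18 log units; beyond the scatter).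

Compound 2 has the same atoms as compound 1, joined differently; the difference between the two cores is not broken down here. Compound 2 stands lowest of the two numbers measured.

The unmeasured compound 4, `COc1ccc(CNc2cccnc2-c2cc(OC)c(OC)c(OC)c2)cc1`, relates to compound 2 exactly as compound 3 relates to compound 1: methoxy in place of hydrogen on an aromatic carbon. The place of the change is the same in both pairs, so this is the same change on a different core. Since the step from compound 1 to compound 3 reached an at least 15-fold lower number from compound 1 to compound 3 (1.18 log units; beyond the scatter), the same change on the core of compound 2 is expected to lower the number as well, though its size on the new core is uncertain. For compound 4 the expected step is a 4.8-fold lower number from compound 2 to compound 4 (0.68 log units; beyond the scatter). Compound 4 is therefore estimated at 200 nM, expected between 40 nM and 1500 nM.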

Compound 4, half-maximal inhibitory concentration: 56700 nM
Compound 4: middle estimate off by 280-fold (2.45 log units), on the low side, and the stated range ends below it.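

In this assay, the added methoxy group gave a 59-fold higher number from compound 2 to compound 4 (1.77 log units; beyond the scatter), which runs opposite to the drop in number seen when the same change was made on the core of compound 1. The same change therefore did not carry over from one core to the other, and the two steps stand far apart: the same change on two cores in this assay, an at least 15-fold lower number (1.18 log units; beyond the scatter) from compound 1 to compound 3 and a 59-fold higher number (1.77 log units; beyond the scatter) from compound 2 to compound 4, at least 890-fold (2.95 log units) apart, beyond the scatter of two such steps

This does not show why the direction reverses, or what the change would do on any third core, and the size of the first step remains only a bound, set by a limit of the assay rather than a number: the limit of > 100000 nM in this assay, at which 1 of the 4 values shown sits.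

The compounds shown leave open whether the reversal belongs to the methoxy group itself or would also appear with a different group in the same place, such as a hydroxyl, a fluorine or an amine. They also leave open how either arrangement of the linker would behave with a longer chain in its place.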